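This account rests on a few compounds, and the source may have more. Where it says the series, first, only, none or still open, it means among the compounds named here.

Measured so far:
compound 1 `CC(C)=CCOc1cc(Nc2ncccn2)ccc1Cl` — 2500 nM
compound 2 `CC(C)=CCOc1cc(Nc2nccs2)ccc1C` — 17000 nM

In a functional assay on MT2 cells (Homo sapiens) for cytotoxicity (a higher number here means that more compound is tolerated, a lower number that less compound is tolerated), compound 2 gives the highest of the two numbers; compound 1 gives a number lower than this, beyond the scatter. Within the data shown here, the two structures differ in more than one place, so no single step links them. Compound 3 `CC(C)=CCOc1cc(Nc2ncccn2)ccc1C` is the next compound, not yet measured in this assay. It differs from compound 2 by pyrimidin-2-yl in place of 1,3-thiazol-2-yl on a nitrogen on an aromatic ring. Compound 1, which carries pyrimidin-2-yl, gives the lower number, but it also differs elsewhere, so the step from compound 2 to compound 3 is expected to be a moderate decrease of a 2.4-fold lower number from compound 2 to compound 3 (0.39 log units; beyond the scatter), with wide uncertainty. Compound 3 is estimated at 7000 nM (range 2500 nM to 20000 nM).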

Compound 3, half-maximal cytotoxic concentration: 78000 nM
Estimate against measurement, compound 3: 11-fold (1.05 log units) below; measured number above the stated range.
By their numbers in this assay, from the lowest: compound 1; then compound 2; then compound 3.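

In this assay, pyrimidin-2-yl in place of 1,3-thiazol-2-yl on a nitrogen on an aromatic ring gives a 4.6-fold higher number from compound 2 to compound 3 (0.66 log units; beyond the scatter), so taken alone this change raises the number. Methyl in place of chloro on an aromatic carbon gives a 31-fold higher number from compound 1 to compound 3 (1.49 log units; beyond the scatter), a large step, which ties the low number of compound 1 to the chloro and not to pyrimidin-2-yl. Nothing at hand accounts for either step. Still open, as far as these compounds go, is whether the chloro step recurs with 1,3-thiazol-2-yl on the nitrogen, and how fluoro or methoxy on that aromatic carbon would compare.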